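Removing the methyl from compound 2

The compounds below may be only part of what the source reports. "The series", "measured", "known", "first", "only" and "open" are said of these compounds alone.

Compound 1 `COc1cc(N2C(=O)C3(CCC3)N(c3ccc(OC4CCN(C)CC4)nc3)C2=S)cnc1C#N`: 116%
Compound 2 `CN1CCC(Oc2ccc(N3C(=S)N(c4cnc(C#N)c(C(F)(F)F)c4)C(=O)C34CCC4)cn2)CC1`: 56%
Compound 3 `COc1cc(N2C(=O)C3(CCC3)N(c3ccc(OC4CCN(C)CC4)cc3)C2=S)cnc1C#N`: 87%

These three compounds have been measured in an ADME assay on the whole organism (Mus musculus, strain CD1) for pharmacokinetics, at a dose of 10 mg/kg by the oral route; on this read-out lower numbers stand for lower oral bioavailability and higher numbers for higher oral bioavailability. Compound 2 gives 56%, the lowest of the three numbers. Its gaps to compound 3 at 87% and to compound 1 at 116% both lie beyond the scatter.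

Compound 4 `N#Cc1ncc(N2C(=O)C3(CCC3)N(c3ccc(OC4CCNCC4)nc3)C2=S)cc1C(F)(F)F` has not yet been measured in this assay. It comes from compound 2 by one change hydrogen in place of methyl on an amine nitrogen in a ring, so that 1-methylpiperidin-4-yl becomes piperidin-4-yl.

Among the compounds with values here, the one measured single-place step, a number 60 percentage points lower from compound 1 to compound 2 (beyond the scatter), is large, but it is a different change, trifluoromethyl in place of methoxy on an aromatic carbon. Within the data shown here, no measured pair shows the change at the amine nitrogen, so its size remains unknown. A small fall is expected, an estimated a number 11 percentage points lower from compound 2 to compound 4 (beyond the scatter). The range is kept wide because a number 60 percentage points lower from compound 1 to compound 2 (beyond the scatter) shows how far one change can move these numbers. The estimate for compound 4 is 45%, with an expected range from 22% to 70%.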

Compound 4, oral bioavailability: 45%
Beside the measured number, compound 4's estimate shows no gap at the digits printed; measured number inside the range.
By their numbers in this assay, from the lowest: compound 4; then compound 2; then compound 3; then compound 1.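

In this assay, within the data shown here, hydrogen in place of methyl on an amine nitrogen in a ring gives a number 11 percentage points lower from compound 2 to compound 4 (beyond the scatter), a modest step and the first reading of any change at this position. Going from 1-methylpiperidin-4-yl to piperidin-4-yl therefore moves the number much less than trifluoromethyl in place of methoxy on an aromatic carbon, which gave a number 60 percentage points lower from compound 1 to compound 2 (beyond the scatter). The data shown give no reason for the fall at the amine nitrogen.

Going by these compounds, it remains open whether hydrogen in place of methyl would give a step of similar size with the methoxy group of compound 1 in place of trifluoromethyl. Also open, on these data alone, is how an ethyl or an acetyl group on the same amine nitrogen would compare with methyl and hydrogen.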